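The source may report more compounds than this note shows. Statements on the series, on what has been measured and on what is new or still open speak of the compounds shown alone.

This account follows the change from compound 2 `O=C(N[C@H](CO)C(=O)NO)c1ccc(C#Cc2ccccc2)cc1` to compound 4 `CC(C)(NC(=O)c1ccc(C#Cc2ccccc2)cc1)C(=O)NO`, which has not yet been measured. In a physicochemical assay for lipophilicity (on this read-out higher numbers stand for higher lipophilicity and lower numbers for lower lipophilicity), compound 2 gives 2, the lowest of the two numbers shown. Compound 3 `O=C(NC1(C(=O)NO)CCNCC1)c1ccc(C#Cc2ccccc2)cc1` gives 3 in this assay, a step above compound 2 that lies beyond the usual scatter. Compound 1 `O=C(NC1(C(=O)NO)CCOCC1)c1ccc(C#Cc2ccccc2)cc1` reaches only a limit of the assay in this assay, > 4, which is not a number (the limit of > 4 in this assay, at which 1 of the 3 values shown sits). Compound 4 differs from compound 2 in one place: a group of 7 heavy atoms (4 carbon, 1 nitrogen, 2 oxygen; no ring) in place of a group of 7 heavy atoms (3 carbon, 1 nitrogen, 3 oxygen; no ring), on an amide-type nitrogen. No step of this kind has been measured among the compounds shown. A rise beyond the scatter is nonetheless expected in this assay, estimated as a number 1.30 log units higher from compound 2 to compound 4 (beyond the scatter). Compound 4 is accordingly estimated at 3.3 in this assay, with a range from 2.7 to 3.9.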

Compound 4, distribution coefficient: 3
Compound 4: middle estimate off by 0.30 log units, on the high side; the range from low to high includes it.
By their numbers in this assay, from the lowest: compound 2; then compounds 3 and 4 (each within the scatter of the next). At a limit, above all of these: compound 1.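

For the compounds shown here, at this amide-type nitrogen, 1-(hydroxycarbamoyl)-1-methylethyl in place of the group carried by compound 2 gives, in this assay, a number 1.00 log units higher from compound 2 to compound 4 (beyond the scatter) and this is the first step read at this place. Compound 4 gives 3 and compound 3 gives 3 on the same read-out, within the scatter of each other. Nothing measured here bears on why the step has this size.

Still open, from the compounds shown here alone, is how a group carrying an amine, a carboxylic acid or a longer chain at this place would read in this assay and whether any such group would come close to the limit reached by compound 1.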